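Working notes: from methyl to isopropyl on nitrogen

A few compounds are considered here, and "the series" means these few. Any claim that something is new, unique, unknown or untested is made for them only; others in the source may bear on it.

Measured in a functional assay on MKN-45 cells (Homo sapiens) for inhibition, with a stated time of 72 h; a lower number here means a stronger inhibitor, a higher number a weaker inhibitor:
- compound 1 `COc1cc(C(=O)n2ccc3ccccc32)cc(OC)c1OC` gives 5200 nM
- compound 2 `COc1cc(C(=O)c2ccc3cc[nH]c3c2)cc(OC)c1OC` gives 480 nM
- compound 3 `COc1cc(C(=O)c2ccc3c(ccn3C)c2)cc(OC)c1OC` gives 11.2 nM

Compound 3 has the lowest number of the three, and its distance from both compound 2 and compound 1 lies beyond the scatter. The next compound to be tested is compound 4 `COc1cc(C(=O)c2ccc3c(ccn3C(C)C)c2)cc(OC)c1OC`, which carries isopropyl in place of methyl on an aromatic nitrogen of a five-membered aromatic ring with 1 nitrogen, part of a fused or bridged system of two rings (isopropyl in place of methyl on an aromatic nitrogen).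

Within the data shown here, no measured pair differs in one place only, so the series offers no direct precedent for this change, and the expectation below is a judgement. With compound 3 already at 11.2 nM, a rise in the number seems more likely than a further drop. The expected move is a weakening beyond the scatter, an estimated step of a 5.4-fold higher number from compound 3 to compound 4 (0.73 log units; beyond the scatter). For compound 4 the estimated value is 60 nM, with an expected range of 15 nM to 300 nM.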

Compound 4, half-maximal inhibitory concentration: 470 nM
The estimate for compound 4 lay 7.8-fold (0.89 log units) below the measured number; measured number above the stated range.
By their numbers in this assay, from the lowest: compound 3; then compounds 4 and 2 (each within the scatter of the next); then compound 1.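

In this assay, among these compounds, isopropyl in place of methyl on an aromatic nitrogen gives a 42-fold higher number from compound 3 to compound 4 (1.62 log units; beyond the scatter), the first change confined to one place. It shows that this nitrogen substituent is not a neutral point on the shared core: on this single pair, methyl is kept as the far better of the two groups, and the step lies well beyond the scatter. Nothing available explains the size of this loss.

Still open, as far as these compounds go, is whether ethyl or cyclopropyl on this nitrogen stays close to compound 3 or already follows compound 4. Equally open, from the compounds shown here alone, is whether a longer chain ending in an amine or a carboxylic acid is treated like isopropyl, since one pair cannot set a trend for this position.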